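The compounds below may be only part of what the source reports. "The series", "measured", "known", "first", "only" and "open" are said of these compounds alone.

Three compounds share one core and differ only in the group on one aromatic ring. Compound 1 `Clc1ccc(C2CC(c3ccccc3)=NN2c2ccc(-c3ccccc3)nn2)cc1` carries a chloro there, compound 2 `Fc1ccc(C2CC(c3ccccc3)=NN2c2ccc(-c3ccccc3)nn2)cc1` a fluoro, and compound 3 `FC(F)(F)c1ccc(C2CC(c3ccccc3)=NN2c2ccc(-c3ccccc3)nn2)cc1` a trifluoromethyl. In a functional assay on HepG2 cells (Homo sapiens) for antiproliferative activity, read by MTT assay, with a stated time of 24 h (a lower number here means a stronger inhibitor, a higher number a weaker inhibitor), compound 1 gives 6310 nM, compound 2 gives 8420 nM, and compound 3 gives 10000 nM. The steps among them, a 1.3-fold higher number from compound 1 to compound 2 (0.13 log units; within the scatter), a 1.6-fold higher number from compound 1 to compound 3 (0.20 log units; within the scatter) and a 1.2-fold higher number from compound 2 to compound 3 (0.07 log units; within the scatter), all lie within the scatter, so compound 2 sits among three numbers that the scatter does not separate, its own number falling between the other two. Compound 4 `Fc1ccc(C2CC(c3ccc(Cl)cc3)=NN2c2ccc(-c3ccccc3)nn2)cc1` keeps the fluoro of compound 2 and adds a group on the other aromatic ring: chloro in place of hydrogen on an aromatic carbon. For the measured compounds named here, no measured step makes this exact change; the known steps only exchange one small group for another on a different ring, and each moved the number little. With nothing pointing either way, the expected step is small: a 1.1-fold lower number from compound 2 to compound 4 (0.05 log units; within the scatter). In this assay compound 4 is estimated at 7500 nM, with a likely range from 3000 nM to 18000 nM.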

Compound 4, half-maximal inhibitory concentration: 10000 nM
Compound 4: the middle estimate sits 1.3-fold (0.12 log units) below what was measured, within the range that was stated.
By their numbers in this assay, from the lowest: compounds 1, 2, 3 and 4 (each within the scatter of the next).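

The earlier steps shown here only exchanged one small group for another on a single aromatic ring, while compound 4 brings a change on the other aromatic ring, where chloro replaces hydrogen, para to a large group, and turns phenyl into 4-chlorophenyl. In this assay this change gives a 1.2-fold higher number from compound 2 to compound 4 (0.07 log units; within the scatter) and so does not set the two compounds apart. On this ring, as with the exchanges on the first, a single small group leaves the number within the scatter. No measurement shown here offers an explanation for this result.

Still open, on these data alone, is whether a different group at this place, such as an amine or a carboxylic acid, would give a step beyond the scatter. As far as these compounds go, a longer chain on either aromatic ring remains an equally open question.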